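Allyl in Place of Methoxyethyl: An Expected Step

A few compounds are considered here, and "the series" means these few. Any claim that something is new, unique, unknown or untested is made for them only; others in the source may bear on it.

Of the compounds shown here, three sharing one core have been measured in an assay on isolated protein for inhibition of Amine oxidase [flavin-containing] A (Homo sapiens), read by fluorescence and Amplex Red, with a stated time of 30 min, tested at 1 uM; a lower number here means a weaker effect, a higher number a stronger effect of the compound at the concentration tested. Compound 1 `CCCNc1nnc(SCC(=O)N(Cc2cccc([N+](=O)[O-])c2)c2ccc(F)cc2)s1` gives 62.3%. Compound 2 `CC(C)CNc1nnc(SCC(=O)N(Cc2cccc([N+](=O)[O-])c2)c2ccc(F)cc2)s1` gives 43.2%, which is a change of a number 19.1 percentage points lower from compound 1 to compound 2 (beyond the scatter). Compound 3 `COCCNc1nnc(SCC(=O)N(Cc2cccc([N+](=O)[O-])c2)c2ccc(F)cc2)s1` gives 72.7%, the highest of the three numbers; the nearest to it is compound 1 and the furthest compound 2, as shown by a number 10.4 percentage points higher from compound 1 to compound 3 (beyond the scatter) and a number 29.5 percentage points higher from compound 2 to compound 3 (beyond the scatter).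

The step now considered leads to compound 4 `C=CCNc1nnc(SCC(=O)N(Cc2cccc([N+](=O)[O-])c2)c2ccc(F)cc2)s1`, which differs from compound 3 as follows: vinyl in place of methoxymethyl on a saturated chain carbon bound to a nitrogen on an aromatic ring. Of the measured chains, propyl in compound 1 is the closest relative of allyl, so the step from compound 1 to compound 3 bears on the change most; it was a modest rise when methoxy replaced methyl, and read in reverse it points to a modest fall. The step from compound 1 to compound 2 shows that a branch on the chain lowered the number further, but allyl carries no branch. A modest decrease is therefore expected, of about a number 12.7 percentage points lower from compound 3 to compound 4 (beyond the scatter). Compound 4 is expected to give 60% in this assay, within a range from 45% to 75%.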

Compound 4, a percentage reported as inhibition, at one concentration (the size of the read-out at that concentration, not a potency): 56.5%
Estimate against measurement, compound 4: 3.5 percentage points above; the range from low to high includes it.
By their numbers in this assay, from the lowest: compound 2; then compounds 4 and 1 (each within the scatter of the next); then compound 3.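

Within the shared core, the double bond of allyl makes no readable difference from the saturated propyl chain, with a number 5.8 percentage points lower from compound 1 to compound 4 (within the scatter) in this assay; the earlier compounds had not shown how far an unbranched chain without oxygen could be altered at this position. The step to allyl from 2-methoxyethyl, a number 16.2 percentage points lower from compound 3 to compound 4 (beyond the scatter), gives a second unbranched chain without oxygen that stands clearly apart from compound 3, so the high number of compound 3 no longer rests on the comparison with propyl alone. Allyl also stands clear of the branched chain, with a number 13.3 percentage points higher from compound 2 to compound 4 (beyond the scatter), so among these four compounds the isopropyl-ended chain of compound 2 and the 2-methoxyethyl chain of compound 3 mark the two ends, while allyl and propyl share the middle ground.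

Nothing given here explains why these chains differ.

From the compounds shown here alone, whether the oxygen atom of 2-methoxyethyl matters as such, or only its place along the chain, remains open, and a 2-hydroxyethyl or a 3-methoxypropyl chain would bear on that question. A propargyl chain, a cyclopropylmethyl group or a chain ending in an amine would show how far the middle ground of allyl and propyl extends.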